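From 4-methoxyphenyl to 3,4-dichlorophenyl: working notes

The source may report more compounds than this note shows. Statements on the series, on what has been measured and on what is new or still open speak of the compounds shown alone.

Within the data shown here, the series so far holds three measured entries on a shared core, tested in a functional assay on HCT-116 cells (Homo sapiens) for cytotoxicity, read by MTT assay, with a stated time of 48 h; on this read-out higher numbers stand for weaker inhibition and lower numbers for stronger inhibition. Compound 1 `O=c1ccc2cc(OCc3cc(-c4ccccc4Cl)no3)ccc2o1` stands at "not determined" (no result reported) with no reported result, so it adds nothing to the comparison. Compound 2 `O=c1ccc2cc(OCc3cc(-c4cccc([N+](=O)[O-])c4)no3)ccc2o1` gives 48200 nM, and compound 3 `COc1ccc(-n2cc(COc3ccc4oc(=O)ccc4c3)nn2)cc1` gives 37800 nM. These two numbers lie within the scatter of each other, so compound 3 stands level with compound 2, and both sit in the same high range of this assay.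

The next entry is compound 4 `O=c1ccc2cc(OCc3cn(-c4ccc(Cl)c(Cl)c4)nn3)ccc2o1`, which carries 3,4-dichlorophenyl in place of 4-methoxyphenyl on an aromatic nitrogen of a five-membered aromatic ring with 3 nitrogen: 3,4-dichlorophenyl in place of 4-methoxyphenyl on an aromatic nitrogen. Among the measured compounds shown here, no step between measured compounds that differ in one place is available, so the size of this change has no direct precedent. For the measured compounds named here, the only anchors are compound 3 at 37800 nM and compound 2 at 48200 nM. A small shift towards a lower number is expected, most likely not beyond the scatter, and the uncertainty is wide in both directions. The estimated change is a 1.3-fold lower number from compound 3 to compound 4 (0.10 log units; within the scatter). For compound 4 the expected value is 30000 nM, with an estimated range from 10000 nM to 80000 nM.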

Compound 4, half-maximal inhibitory concentration: 57300 nM
The estimate for compound 4 lay 1.9-fold (0.28 log units) below the measured number; the measured number falls inside the stated range.
By their numbers in this assay, from the lowest: compounds 3, 2 and 4 (each within the scatter of the next).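

Among these compounds, with 3,4-dichlorophenyl in place of 4-methoxyphenyl on an aromatic nitrogen of the five-membered aromatic ring with 3 nitrogen, this assay gives a 1.5-fold higher number from compound 3 to compound 4 (0.18 log units; within the scatter) as the first step between compounds that differ in one place. This position therefore accepts both aryl groups with no separation beyond the scatter, even though the 4-methoxyphenyl group counts 1 hydrogen-bond acceptor and the 3,4-dichlorophenyl group counts 0, and the two groups hold the same count of heavy atoms. No measurement at hand bears on the reason for this result.

The two aryl groups alone leave open whether any group on this aromatic nitrogen can move the number out of the high range, for example a phenyl ring carrying an amine or a carboxylic acid, or a longer alkyl chain in place of the phenyl ring. On these data alone, compound 2 differs from compound 3 and compound 4 in more than one place, so the link between the shared core and the attached five-membered ring also remains open.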